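This account rests on a few compounds, and the source may have more. Where it says the series, first, only, none or still open, it means among the compounds named here.

In an assay on nucleic acid with ribosomal RNA A-site as the target (a higher number here means weaker binding, a lower number tighter binding), compound 1 `NC1C[C@@H](N)[C@@H](O)C(O)[C@H]1OCSc1ccnc2cc(C(F)(F)F)ccc12` gives 35000 nM and compound 2 `COc1ccc(CO[C@H]2C(N)C[C@@H](N)[C@@H](O)C2O)cc1` gives 315000 nM. Compound 3 `NCCCNCCOC1[C@@H](OCSc2ccnc3cc(C(F)(F)F)ccc23)C(N)C[C@@H](N)[C@H]1O` gives 2000 nM, the lowest number of the three. Compound 4 `CN(C)CCCNC(=O)COC1[C@@H](OCSc2ccnc3cc(C(F)(F)F)ccc23)C(N)C[C@@H](N)[C@H]1O` differs from compound 3 by one change: (3-(dimethylamino)propyl)carbamoyl in place of ((3-aminopropyl)amino)methyl on a saturated chain carbon bound to an oxygen on a saturated carbon. It carries (3-(dimethylamino)propyl)carbamoyl in place of ((3-aminopropyl)amino)methyl on a saturated chain carbon bound to an oxygen on a saturated carbon. Within the data shown here, the one measured step that bears on this is an 18-fold lower number from compound 1 to compound 3 (1.24 log units; beyond the scatter), a large step that came with adding the 2-((3-aminopropyl)amino)ethyl chain. Among the measured compounds shown here, no measured step alters such a chain once it is present, so only part of that gain is expected to be given back. The expected step is a 3.0-fold higher number from compound 3 to compound 4 (0.48 log units; beyond the scatter), towards a higher number. For compound 4 the estimated value is 6000 nM, with an expected range of 2000 nM to 18000 nM.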

Compound 4, dissociation constant: 88000 nM
The estimate for compound 4 lay 15-fold (1.17 log units) below the measured number, and the stated range ends below it.
By their numbers in this assay, from the lowest: compound 3; then compound 1; then compound 4; then compound 2.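

In this assay the gain at this oxygen proves to depend on the chain itself: (3-(dimethylamino)propyl)carbamoyl in place of ((3-aminopropyl)amino)methyl gives a 44-fold higher number from compound 3 to compound 4 (1.64 log units; beyond the scatter) and more than cancels that gain. Measured against hydrogen on the same oxygen, the new chain gives a 2.5-fold higher number from compound 1 to compound 4 (0.40 log units; beyond the scatter) and so does not merely fall short of the earlier chain, but raises the number. No evidence at hand explains this change. The compounds leave open whether the loss follows the carbonyl or the two methyl groups on the terminal amine. A chain with a secondary amine and a terminal dimethylamino group would separate the two.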